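From 2-bromophenyl to 4-fluorophenyl on a shared core

The compounds below may be only part of what the source reports. "The series", "measured", "known", "first", "only" and "open" are said of these compounds alone.

Among the compounds with values here, in a functional assay on Ehrlich cells (Mus musculus) for cytotoxicity, read by LDH release, with a stated time of 48 h (on this read-out higher numbers stand for weaker inhibition and lower numbers for stronger inhibition), compound 1 `Cc1ccc(OCC(=O)NNC(=O)c2cc3ccccc3oc2=O)c(C(=O)c2ccccc2Br)c1` gives 9400 nM, the lowest of the three numbers so far and therefore the strongest inhibition among them. Compound 2 `Cc1ccc(OCC(=O)NNC(=O)c2cc3ccccc3oc2=O)c(C(=O)c2ccc(Cl)cc2)c1` gives 58000 nM, and compound 3 `Cc1ccc(OCC(=O)NNC(=O)c2cc3ccccc3oc2=O)c(C(=O)c2cccc(Br)c2)c1` gives 68100 nM.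

Compound 4 `Cc1ccc(OCC(=O)NNC(=O)c2cc3ccccc3oc2=O)c(C(=O)c2ccc(F)cc2)c1` has not been measured yet. It keeps the core of compound 1 but has 4-fluorophenyl in place of 2-bromophenyl on a carbonyl carbon.

Within the data shown here, two measured steps bear on this change. Putting 4-chlorophenyl in place of 2-bromophenyl gave a 6.2-fold higher number from compound 1 to compound 2 (0.79 log units; beyond the scatter), and putting 3-bromophenyl there gave a 7.2-fold higher number from compound 1 to compound 3 (0.86 log units; beyond the scatter). Both are modest, beyond the scatter and in the same direction, while the remaining step, a 1.2-fold higher number from compound 2 to compound 3 (0.07 log units; within the scatter), is within the scatter. Among the measured compounds shown here, no measured compound carries a 4-fluorophenyl, so compound 2, with its 4-chlorophenyl and 58000 nM, is the nearest guide. A modest step towards a higher number is therefore expected, and the estimate is a 6.4-fold higher number from compound 1 to compound 4 (0.81 log units; beyond the scatter). Compound 4 is expected to give about 60000 nM, with an estimated range of 25000 nM to 130000 nM.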

Compound 4, half-maximal inhibitory concentration: 40800 nM
For compound 4 the middle estimate is 1.5-fold (0.17 log units) above the measured one, within the range that was stated.
By their numbers in this assay, from the lowest: compound 1; then compounds 4, 2 and 3 (each within the scatter of the next).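

Fluoro in place of chloro on an aromatic carbon gives a 1.4-fold lower number from compound 2 to compound 4 (0.15 log units; within the scatter) and 4-fluorophenyl in place of 3-bromophenyl gives a 1.7-fold lower number from compound 3 to compound 4 (0.22 log units; within the scatter) so in this assay neither step separates compound 4 from compounds 2 and 3. Replacing 2-bromophenyl with 4-fluorophenyl gives a 4.3-fold higher number from compound 1 to compound 4 (0.64 log units; beyond the scatter) which makes this the third replacement of the 2-bromophenyl group to end beyond the scatter, leaving compound 1 alone with the lowest number and the strongest inhibition of the four. Nothing measured here explains why compound 1 stands apart.

From the compounds shown here alone, it remains open whether the separation belongs to bromine itself or would also appear with 2-chlorophenyl, 2-fluorophenyl or 2-methylphenyl on the same carbonyl carbon. An unsubstituted phenyl would show how any of these halogen-bearing groups compares with no substituent at all.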